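Trimming the Ether Chain on a Cyclopropane Hydrazide Series

This account rests on a few compounds, and the source may have more. Where it says the series, first, only, none or still open, it means among the compounds named here.

Compound 1, `O=C(NNC(=O)C1CC1c1ccc(OC(F)(F)F)cc1)c1ccncc1`: in a functional assay on PC-3 cells (Homo sapiens) for inhibition, read by MTT assay, with a stated time of 72 h (a higher number here means a weaker inhibitor, a lower number a stronger inhibitor), compound 1 gives > 100000 nM, which is a limit of the assay.
Compound 2, `CC(C)=CCC/C(C)=C/COc1ccc(C2CC2C(=O)NNC(=O)c2ccncc2)cc1`: compound 2 gives > 100000 nM, again a limit.
Compound 3, `O=C(NNC(=O)C1CC1c1ccc(OCC(F)(F)F)cc1)c1ccncc1`: compound 3 gives 44000 nM.

Going by the values given here, compound 3 therefore stands as the only member of the series with a measured number; the other two values sit at the limit of > 100000 nM in this assay, at which 2 of the 3 values shown sit. The step of an at least 2.2-fold lower number from compound 1 to compound 3 (0.35 log units; beyond the scatter) and the step of an at least 2.2-fold lower number from compound 2 to compound 3 (0.35 log units; beyond the scatter) both reach compound 3 from a limit, so their full size is not readable, and the step that the two limits leave unreadable from compound 1 to compound 2 between two limits cannot be read at all.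

Compound 4, `COc1ccc(C2CC2C(=O)NNC(=O)c2ccncc2)cc1`, differs from compound 3 by hydrogen in place of trifluoromethyl on a saturated chain carbon bound to an oxygen on an aromatic ring. Among the compounds with values here, no measured step covers this exact change; the nearest evidence is that the trifluoroethoxy group of compound 3 gave a number where the trifluoromethoxy group of compound 1 and the long dienyl ether of compound 2 did not. Shortening the chain further moves away from the one substituent that produced a reading, so the expected step of a 2.0-fold higher number from compound 3 to compound 4 (0.31 log units; beyond the scatter) is a weakening, possibly back to the limit. Compound 4 is thus expected to give about 90000 nM in this assay, with a range from 25000 nM to 300000 nM.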

Compound 4, half-maximal inhibitory concentration: > 100000 nM
Compound 4: a limit, no number; the forecaster's own chance of this, stated with the estimate: 50%; middle value at least 1.1-fold (0.04 log units) away from the limit.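

In this assay, going by these compounds alone, putting hydrogen in place of trifluoromethyl on a saturated chain carbon bound to an oxygen on an aromatic ring gives an at least 2.2-fold higher number from compound 3 to compound 4 (0.35 log units; beyond the scatter), so this terminal group cannot be removed without losing the only reading; the full size of the step is hidden, as it ends at a limit. The earlier compounds had shown that the trifluoromethoxy group of compound 1 and the long dienyl ether of compound 2 reach no number, and the short methoxy group of compound 4 now joins them, leaving 2,2,2-trifluoroethoxy in compound 3 as the only ether shown that gives one. The steps from compound 1 and compound 2 to compound 4 join two limits and cannot be read, and the series now rests on a single number: the limit of > 100000 nM in this assay, at which 3 of the 4 values shown sit.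

The compounds shown leave open whether a plain ethyl ether, with no fluorine on the chain, would also give a number, which would separate the effect of chain length from that of the fluorine atoms. They also leave open how a longer fluorinated chain, or an amine at the end of the chain, would read at this position.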